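A few compounds are considered here, and "the series" means these few. Any claim that something is new, unique, unknown or untested is made for them only; others in the source may bear on it.

Among the compounds with values here, compound 1 `CCOC(CCn1c(Cc2nn(C)c(=O)c3ccccc23)nnc1SCCCCCCCC(=O)Nc1ccc(Cl)cc1Cl)OCC` is the only compound here with a number of its own. In an assay on 32D cells for inhibition of interleukin-15 (Mus musculus), read by resazurin assay, with stated times of 30 min and 2.5 days, in the presence of a further agent that is not named here (a higher number here means a weaker inhibitor, a lower number a stronger inhibitor), compound 1 gives 16400 nM. Compound 2 `Cn1nc(Cc2nnc(SCC(=O)Nc3ccc(Cl)cc3Cl)n2CCC(=O)O)c2ccccc2c1=O` is the other measured member of the pair. In this assay compound 2 returns only a limit, > 30000 nM, and no number. Of the values shown, one sits at the limit of > 30000 nM in this assay, at which 1 of the 2 values shown sits, so compound 1 stands as the sole numbered point. Compound 3 `Cn1nc(Cc2nnc(SCCCCCCCC(=O)Nc3ccc(Cl)cc3Cl)n2CCCO[Si](C)(C)C(C)(C)C)c2ccccc2c1=O` has not yet been measured. It differs from compound 1 in one place, (a group of 9 heavy atoms (7 carbon, 1 oxygen, 1 silicon; no ring) in place of a group of 7 heavy atoms (5 carbon, 2 oxygen; no ring), on a saturated chain carbon, two bonds along the chain from an aromatic nitrogen), a group of 9 heavy atoms (7 carbon, 1 oxygen, 1 silicon; no ring) in place of a group of 7 heavy atoms (5 carbon, 2 oxygen; no ring), on a saturated chain carbon, two bonds along the chain from an aromatic nitrogen. Within the data shown here, no measured pair shows what such a swap does in this assay. With nothing pointing either way, the expected step is a 1.0-fold lower number from compound 1 to compound 3 (0.01 log units; within the scatter), no larger than the scatter. Compound 3 is therefore estimated at 16000 nM in this assay, within a range from 6000 nM to 40000 nM.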

Compound 3, half-maximal inhibitory concentration: > 30000 nM
Compound 3: no number, only a limit; the forecaster's own chance of this, stated with the estimate: 30%; middle value at least 1.8-fold (0.27 log units) from the limit.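

Replacing diethoxymethyl with the group of 9 heavy atoms (7 carbon, 1 oxygen, 1 silicon), on a saturated chain carbon, two bonds along the chain from an aromatic nitrogen, gives an at least 1.8-fold higher number from compound 1 to compound 3 (0.26 log units; that floor lies within the scatter) in this assay. For compound 3 the read-out is only a limit, > 30000 nM, so this first readable step at this position shows no gain from the swap, yet it does not establish a loss beyond the scatter. The limit now holds most of the compounds shown: the limit of > 30000 nM in this assay, at which 2 of the 3 values shown sit.

From the compounds shown here alone, how far compound 3 lies past its limit, and so the true size of the step, stays open. Also open, going by these compounds, is whether an amine or a free hydroxyl at this place, with the rest of compound 1 kept, would give a lower number.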